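A few compounds are considered here, and "the series" means these few. Any claim that something is new, unique, unknown or untested is made for them only; others in the source may bear on it.

Working notes on the series. Among the measured compounds shown here, in an assay for inhibition of high affinity nerve growth factor receptor (Homo sapiens), read by HTRF, with a stated time of 30 min, in the presence of a further agent that is not named here (on this read-out higher numbers stand for weaker inhibition and lower numbers for stronger inhibition), compound 3 `Cc1cc(Nc2nc(NCc3ccc(F)c(F)c3)nc3ccccc23)n[nH]1` gives 74 nM and stands second highest of the three numbers measured so far. Its nearest neighbour is compound 1 `Cc1ccc(CNc2nc(Nc3cc(C)[nH]n3)c3ccccc3n2)cc1` with 110 nM in this assay, the two lying within the scatter of each other (a 1.5-fold lower number from compound 1 to compound 3 (0.17 log units; within the scatter)). Compound 2 `Cc1cc(Nc2nc(NCc3cc(F)ccc3F)nc3ccccc23)n[nH]1` is furthest, giving 7.5 nM in this assay, with a 9.9-fold higher number from compound 2 to compound 3 (0.99 log units; beyond the scatter) and a 15-fold lower number from compound 1 to compound 2 (1.17 log units; beyond the scatter).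

Compound 4 `Cc1cc(Nc2nc(NCc3cc(F)cc(F)c3)nc3ccccc23)n[nH]1` differs from compound 3 only in the placement of the two fluorines on the ring: 3,5-difluorophenyl in place of 3,4-difluorophenyl on a saturated chain carbon bound to a nitrogen on an aromatic ring. For the measured compounds named here, no measured step covers this exact change. Going by the values given here, the steps that bear on it show that moving the fluorines around the ring can matter strongly, as in a 9.9-fold higher number from compound 2 to compound 3 (0.99 log units; beyond the scatter), while exchanging the ring of compound 1 for that of compound 3 gave a 1.5-fold lower number from compound 1 to compound 3 (0.17 log units; within the scatter). Because the step of a 9.9-fold higher number from compound 2 to compound 3 (0.99 log units; beyond the scatter) came from moving fluorines alone, a sizeable shift in either direction is possible for compound 4. Compound 4 is therefore expected to give about 45 nM in this assay, in the range 10 nM to 200 nM, meaning an estimated step of a 1.6-fold lower number from compound 3 to compound 4 (0.22 log units; within the scatter).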

Compound 4, half-maximal inhibitory concentration: 170 nM
Estimate against measurement, compound 4: 3.8-fold (0.58 log units) below; measured number inside the range.
By their numbers in this assay, from the lowest: compound 2; then compounds 3, 1 and 4 (each within the scatter of the next, the first and the last beyond it).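

In this assay, exchanging 3,4-difluorophenyl for 3,5-difluorophenyl on a saturated chain carbon bound to a nitrogen on an aromatic ring gives a 2.3-fold higher number from compound 3 to compound 4 (0.36 log units; beyond the scatter) and so shows that a change in fluorine placement can raise the number here, even without any 2,5-difluorophenyl group in the pair. Among the compounds shown here, the low number of the 2,5-difluorophenyl group stands out further with a 23-fold higher number from compound 2 to compound 4 (1.36 log units; beyond the scatter) as the largest step so far, whereas a 1.5-fold higher number from compound 1 to compound 4 (0.19 log units; within the scatter) leaves the 3,5-difluorophenyl and 4-methylphenyl groups indistinguishable. Nothing measured here accounts for these differences.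

Going by these compounds, it remains open whether both fluorines of the 2,5-difluorophenyl group are needed for its low number. A plain phenyl, a monofluorophenyl or a longer chain at this place also remains to be read.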